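The source may report more compounds than this note shows. Statements on the series, on what has been measured and on what is new or still open speak of the compounds shown alone.

Measured compounds:
compound 1, `CN1CCN(c2ccc(Nc3ncc4nc(Nc5ccc(F)cc5)n([C@H]5CCCN(C(=O)CO)C5)c4n3)cc2)CC1`, 1.8 nM in a functional assay on HCC827 cells (Homo sapiens) for antiproliferative activity, read by MTT assay, with a stated time of 72 h; a higher number here means a weaker inhibitor, a lower number a stronger inhibitor
compound 2, `CN1CCN(c2ccc(Nc3ncc4nc(Nc5ccc(F)cc5)n([C@@H]5CCCN(C(=O)CO)C5)c4n3)cc2)CC1`, 66 nM in this assay
compound 3, `CN1CCN(c2ccc(Nc3ncc4nc(Nc5ccc(F)cc5)n([C@H]5CCN(S(=O)(=O)C6CC6)C5)c4n3)cc2)CC1`, 7.5 nM in this assay

Compound 3 stands second highest of the three numbers in this assay: the nearest is compound 1, with a 4.2-fold higher number from compound 1 to compound 3 (0.62 log units; beyond the scatter), and the furthest is compound 2, with an 8.8-fold lower number from compound 2 to compound 3 (0.94 log units; beyond the scatter). Within the data shown here, the largest step in the set is a 37-fold higher number from compound 1 to compound 2 (1.56 log units; beyond the scatter), and the fact that compounds 1 and 2 differ only in the configuration as drawn is the only evidence behind it.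

The step from compound 3 to compound 4 is the change ((hydroxymethyl)carbonyl in place of cyclopropylsulfonyl on an amine nitrogen in a ring), giving compound 4 as `CN1CCN(c2ccc(Nc3ncc4nc(Nc5ccc(F)cc5)n([C@H]5CCN(C(=O)CO)C5)c4n3)cc2)CC1`. Among the measured compounds shown here, no measured pair shows this change on its own. The two steps that bear on it each combine the same exchange of the group on the amine nitrogen with a change of ring size: compound 1 and compound 3 differ in both, as do compound 2 and compound 3. Compound 4 carries the ring of compound 3 and the group on the amine nitrogen of compound 1, and it is drawn with the same configuration as compound 3. Compound 4 is therefore expected to fall near compound 1 and compound 3, with a 1.9-fold lower number from compound 3 to compound 4 (0.27 log units; within the scatter) as the estimated step. Compound 4 is estimated at 4 nM, within 1.5 nM to 12 nM.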

Compound 4, half-maximal inhibitory concentration: 380 nM
For compound 4 the middle estimate is 95-fold (1.98 log units) below the measured one; the measured number lies above the stated range.
By their numbers in this assay, from the lowest: compound 1; then compound 3; then compound 2; then compound 4.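

The exchange on the amine nitrogen of the five-membered ring proves far from neutral in this assay: with the pyrrolidin-3-yl ring held constant, cyclopropylsulfonyl gives way to (hydroxymethyl)carbonyl with a large loss (a 51-fold higher number from compound 3 to compound 4 (1.70 log units; beyond the scatter)). With (hydroxymethyl)carbonyl held constant, the pyrrolidin-3-yl ring in compound 4 gives the weakest inhibitor of the four compounds, set against the piperidin-3-yl ring in either drawn configuration (a 210-fold higher number from compound 1 to compound 4 (2.32 log units; beyond the scatter) and a 5.8-fold higher number from compound 2 to compound 4 (0.76 log units; beyond the scatter)), so within these compounds the effects of ring and nitrogen substituent cannot be read as separate and additive, and the pyrrolidin-3-yl ring is well tolerated only in compound 3, which carries cyclopropylsulfonyl. Nothing shown here accounts for these steps.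

The compounds shown leave open whether cyclopropylsulfonyl would give a comparable number on the piperidin-3-yl ring, and whether the opposite drawn configuration at the pyrrolidin-3-yl ring carbon would matter here. They also leave open whether the sulfonyl link or the cyclopropyl ring carries the difference, which a methylsulfonyl or a cyclopropylcarbonyl group on the same amine nitrogen would begin to separate.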